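A few compounds are considered here, and "the series" means these few. Any claim that something is new, unique, unknown or untested is made for them only; others in the source may bear on it.

Working notes on the series.

Compound 1 `CCC1=C(O)c2c(oc(-c3cc(C)c(OC)cc3C)cc2=O)C(CC)(CC)C1=O` and compound 3 `CCC1=C(O)c2c(oc(-c3cc(C)ccc3C)cc2=O)C(CC)(CC)C1=O` share one core and differ at a single place: hydrogen in place of methoxy on an aromatic carbon. In a functional assay on KB cells (Homo sapiens) for antiproliferative activity, read by sulforhodamine B assay, with a stated time of 3 days (a higher number here means that more compound is needed for the effect, a lower number that less compound is needed), compound 1 gives 36.6 uM, while compound 3 gives 14.5 uM, and the step is a 2.5-fold lower number from compound 1 to compound 3 (0.40 log units; beyond the scatter).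

Compound 2 `CCC1=C(O)c2c(oc(-c3ccc(OC)c(OC)c3OC)cc2=O)C(CC)(CC)C1=O` carries a different substitution on the aryl ring; the difference between its core and that of compound 1 is not broken down here. In this assay compound 2 gives 9.4 uM. Against compound 3 the gap lies within the scatter, against compound 1 it lies beyond it, so no order between compound 2 and compound 3 is claimed.

Compound 4 `CCC1=C(O)c2c(oc(-c3cccc(OC)c3OC)cc2=O)C(CC)(CC)C1=O` is not yet measured. It stands to compound 2 as compound 3 stands to compound 1: hydrogen in place of methoxy on an aromatic carbon. This is the same kind of change, not the same one: in compound 1 the carbon in question is ortho to a methyl group and meta to a methyl group, in compound 2 it is ortho to a methoxy group and meta to a methoxy group, and in both it is para to a large group.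

The expected step here is a 1.6-fold lower number from compound 2 to compound 4 (0.19 log units; within the scatter). This expectation rests on one measured pair, because a 2.5-fold lower number from compound 1 to compound 3 (0.40 log units; beyond the scatter), and on the different surroundings of the place, which argue for a somewhat smaller move. Compound 4 is estimated at 6 uM, with a range from 2.5 uM to 15 uM.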

Compound 4, concentration for half-maximal effect: 35.2 uM
Estimate against measurement, compound 4: 5.9-fold (0.77 log units) below, and the stated range ends below it.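

In this assay, hydrogen in place of methoxy on the aromatic carbon gives a 3.7-fold higher number from compound 2 to compound 4 (0.57 log units; beyond the scatter), so this step runs in the opposite direction to the one seen for the same kind of change on the other pair. The change therefore does not carry over as a fixed step from one core to the other, and the earlier pair alone gives no safe guide to either its size or its direction here: the same change on two cores in this assay, a 2.5-fold lower number (0.40 log units; beyond the scatter) from compound 1 to compound 3 and a 3.7-fold higher number (0.57 log units; beyond the scatter) from compound 2 to compound 4, 9.5-fold (0.98 log units) apart, beyond the scatter of two such steps

This does not show which difference between the two pairs sets the direction, whether the methyl groups around the place in one pair or the methoxy groups around it in the other, and with a single pair on each side it gives no rule for any further core in the series.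

The compounds shown leave open how an amine or a carboxylic acid at this place would behave on either core, since only methoxy and hydrogen are compared there. They also leave open whether a hydroxyl group at this place would follow the methoxy compound or the hydrogen compound of each pair.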